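A 2-Methoxyphenyl Replaces 3-Cyanophenyl on Compound 3

The source may report more compounds than this note shows. Statements on the series, on what has been measured and on what is new or still open speak of the compounds shown alone.

Three analogues sharing one core have been run through an in vitro functional assay on cells for agonist activity at Bombesin receptor subtype-3 (Mus musculus), read by luminescence and calcium flux; a higher number here means that more compound is needed for the effect, a lower number that less compound is needed. Compound 1 `Cc1cccc(Cc2cnc(CCc3ccc(-c4ccccc4C(=O)O)cc3)[nH]2)c1` gives 75 nM. Compound 2 `N#Cc1ccc(Cc2cnc(CCc3ccc(-c4ccccc4C(=O)O)cc3)[nH]2)cc1` gives 723 nM. Compound 3 `N#Cc1cccc(Cc2cnc(CCc3ccc(-c4ccccc4C(=O)O)cc3)[nH]2)c1` gives 20 nM, the lowest number of the three: a 3.8-fold lower number from compound 1 to compound 3 (0.57 log units; beyond the scatter), and a 36-fold lower number from compound 2 to compound 3 (1.56 log units; beyond the scatter). The remaining step, a 9.6-fold higher number from compound 1 to compound 2 (0.98 log units; beyond the scatter), shows the same two changes seen from the other side.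

Compound 4 `COc1ccccc1Cc1cnc(CCc2ccc(-c3ccccc3C(=O)O)cc2)[nH]1` is the untested member. Relative to compound 3 it carries 2-methoxyphenyl in place of 3-cyanophenyl on a saturated chain carbon bound to an aromatic carbon. Among the measured compounds shown here, no measured step involves a 2-methoxyphenyl or any methoxy group, so the known steps bear on this change only indirectly. Where the cyano group was moved around the ring, the step from compound 2 to compound 3 was large; where a group was exchanged for another at the same place, the step from compound 1 to compound 3 was modest. The present change does both at once, which argues for a step beyond the scatter, and the direction is expected to be toward a higher number because compound 3 already holds the lowest value at 20 nM. Compound 4 is therefore estimated at 150 nM, within 30 nM to 800 nM, a step of a 7.5-fold higher number from compound 3 to compound 4 (0.88 log units; beyond the scatter).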

Compound 4, half-maximal effective concentration: 163 nM
Compound 4: the middle estimate sits 1.1-fold (0.04 log units) below what was measured, within the range that was stated.
By their numbers in this assay, from the lowest: compound 3; then compound 1; then compound 4; then compound 2.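

In this assay, the 2-methoxyphenyl shows that this place, on a saturated chain carbon bound to an aromatic carbon, also accepts a methoxy-bearing ring, although it gives up ground against the 3-cyanophenyl (an 8.2-fold higher number from compound 3 to compound 4 (0.91 log units; beyond the scatter)). Among the compounds shown here, the new group falls inside the range already set by the earlier compounds, giving a lower number than the 4-cyanophenyl (a 4.4-fold lower number from compound 2 to compound 4 (0.65 log units; beyond the scatter)) and a higher number than the 3-methylphenyl (a 2.2-fold higher number from compound 1 to compound 4 (0.34 log units; beyond the scatter)), so the 3-cyanophenyl of compound 3 remains the only group at the low end of the four. Nothing in hand explains this order of the four rings.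

The change from compound 3 to compound 4 replaces the group and moves its place on the ring in a single step, so the compounds shown cannot separate the contribution of the methoxy group from that of where it sits. They also leave open how a fluorine, an amine, a hydroxyl or a longer chain would read at this place, and whether any such group could reach a number lower than that of compound 3.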